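The compounds below may be only part of what the source reports. "The series", "measured", "known", "first", "only" and "open" are said of these compounds alone.

Compound 2 `NC(=O)c1c(NC(=O)c2ccccc2Cl)sc2c1CCN(C(=S)Nc1ccccc1F)C2` was tested in a functional assay on HeLa cells (Homo sapiens) for antiproliferative activity, with a stated time of 24 h (on this read-out lower numbers stand for stronger inhibition and higher numbers for weaker inhibition), where compound 2 gives 28700 nM. Its only companion, compound 1 `NC(=O)c1c(NC(=O)c2ccccc2Cl)sc2c1CCN(Cc1cc(Cl)cc(Cl)c1)C2`, gives 19600 nM in this assay, and the step of a 1.5-fold higher number from compound 1 to compound 2 (0.17 log units; within the scatter) stays within the scatter, so the two stand level. Compound 3 `NC(=O)c1c(NC(=O)c2ccccc2Cl)sc2c1CCN(C(=S)Nc1ccccc1-c1ccccc1)C2` differs from compound 2 by phenyl in place of fluoro on an aromatic carbon. Going by the values given here, no measured step touches this aromatic carbon; the single step recorded, on the amine nitrogen in a ring, moved nothing beyond the scatter, so the expected step of a 1.1-fold lower number from compound 2 to compound 3 (0.06 log units; within the scatter) is none beyond the scatter. Compound 3 is therefore estimated at 25000 nM, within a range from 8000 nM to 80000 nM.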

Compound 3, half-maximal inhibitory concentration: 24000 nM
The estimate for compound 3 lay 1.0-fold (0.02 log units) above the measured number; measured number inside the range.
By their numbers in this assay, from the lowest: compounds 1, 3 and 2 (each within the scatter of the next).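

In this assay phenyl in place of fluoro on an aromatic carbon, ortho to a large group, gives a 1.2-fold lower number from compound 2 to compound 3 (0.08 log units; within the scatter) and so the two stand level. Going by these compounds alone, this is the first reading at this position, and it shows that 2-phenylphenyl reads the same as 2-fluorophenyl within the scatter. No measurement at hand offers an explanation for this result. Open, going by these compounds, is how an amine or a carboxylic acid on this aromatic carbon would read, and whether any group here moves the number beyond the scatter.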